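Allyloxy to benzyloxy: working notes on the series

This account rests on a few compounds, and the source may have more. Where it says the series, first, only, none or still open, it means among the compounds named here.

Measured in a functional assay on the whole organism (strain Sprague-Dawley) for inhibition, with Rattus norvegicus as the target, with a stated time of 10 min; a higher number here means that more compound is needed for the effect, a lower number that less compound is needed:
- compound 1 `CCOC(=O)c1cnc(-c2ccccc2OC(C)C)[nH]c1=O`: 2 mg/kg
- compound 2 `C=CCOc1ccccc1-c1ncc(C(=O)OCC)c(=O)[nH]1`: 0.5 mg/kg

For the measured compounds named here, of these two, compound 2 has the lower number, at 0.5 mg/kg so far. Next comes compound 3 `CCOC(=O)c1cnc(-c2ccccc2OCc2ccccc2)[nH]c1=O`, with phenyl in place of vinyl on a saturated chain carbon bound to an oxygen on an aromatic ring, which reads allyloxy to benzyloxy phenyl in place of vinyl on a saturated chain carbon bound to an oxygen on an aromatic ring on the shared core.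

Going by the values given here, only one measured step bears on this: allyl in place of isopropyl gave a 4.0-fold lower number from compound 1 to compound 2 (0.60 log units; beyond the scatter), a modest change beyond the scatter. Among the compounds with values here, no measured compound yet carries phenyl here, so the direction rests on little. A small rise is expected, with a 2.0-fold higher number from compound 2 to compound 3 (0.30 log units; within the scatter) estimated in this assay as the likely step. The estimate for compound 3 is 1 mg/kg (expected range 0.25 mg/kg to 4 mg/kg).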

Compound 3, dose for 50% inhibition: > 5 mg/kg
Compound 3 ended at the assay's limit (the forecaster's own chance of this, stated with the estimate: 5%); middle value at least 5.0-fold (0.69 log units) away from the limit.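

Compound 3 gives (> 5 mg/kg), which is a limit and not a number: the limit of > 5 mg/kg in this assay, at which 1 of the 3 values shown sits.
The earlier pair showed this position moving only one way, with allyl on the oxygen giving the lower number, but the benzyl group moves it up against both neighbours: phenyl in place of vinyl (an at least 10-fold higher number from compound 2 to compound 3 (1.00 log units; beyond the scatter)) and benzyl in place of isopropyl (an at least 2.5-fold higher number from compound 1 to compound 3 (0.39 log units; beyond the scatter)).
The position therefore responds in both directions, and the phenyl on the saturated chain carbon undoes the gain seen with allyl and goes past the isopropyl compound as well.

As far as these compounds go, the true size of both steps stays open, since compound 3 has no number of its own. Also open, from the compounds shown here alone, is whether the gain with allyl depends on its double bond, which a saturated propyl chain or a propargyl group on the same oxygen would separate.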